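The source may report more compounds than this note shows. Statements on the series, on what has been measured and on what is new or still open speak of the compounds shown alone.

Measured compounds:
compound 1 `Nc1cc(N)c2nc(-c3ccccc3)c(Oc3ccc(Cl)c(Cl)c3)nc2c1`: < 100000 nM
compound 2 `CCOC(=O)[C@H](CCC(=O)O)NC(=O)c1ccc(CNc2nc3cc(N)cc(N)c3nc2-c2ccccc2)cc1`: < 100000 nM
compound 3 `CCOC(=O)[C@H](CCC(=O)O)NC(=O)c1ccc(Sc2nc3cc(N)cc(N)c3nc2-c2ccccc2)cc1`: 42700 nM

In a functional assay on HCT-15 cells (Homo sapiens) for inhibition, read by sulforhodamine B assay, with a stated time of 48 h (a higher number here means a weaker inhibitor of growth, a lower number a stronger inhibitor of growth), compound 1 gives < 100000 nM, which is a limit of the assay and not a number. Compound 2 likewise reaches only a limit, < 100000 nM. Compound 3 alone gives a number, 42700 nM. Compound 1 thus sits at the limit of < 100000 nM in this assay, at which 2 of the 3 values shown sit, so its true value is not pinned down. Compound 4 `Nc1cc(N)c2nc(-c3ccccc3)c(NCc3ccc(F)cc3)nc2c1` differs from compound 1 in one place: (4-fluorobenzyl)amino in place of 3,4-dichlorophenoxy on an aromatic carbon, in words (4-fluorobenzyl)amino in place of 3,4-dichlorophenoxy on an aromatic carbon. Going by the values given here, no step between two measured compounds is available to set a scale for this change, so no direction beyond the scatter can be claimed. Compound 4 is expected to remain in the same weak region, at 50000 nM with a range from 15000 nM to 150000 nM. The step from compound 1 to compound 4 is estimated as a step that the limit leaves unreadable from compound 1 to compound 4.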

Compound 4, concentration for total growth inhibition: 19100 nM
The estimate for compound 4 lay 2.6-fold (0.42 log units) above the measured number; measured number inside the range.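

Going by these compounds alone, no step from compound 1 to compound 4 can be read, because compound 1 gives only a limit: the limit of < 100000 nM in this assay, at which 2 of the 4 values shown sit. The compounds shown leave open how much replacing 3,4-dichlorophenoxy with (4-fluorobenzyl)amino changes growth inhibition.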